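Working notes: from compound 2 to compound 3

The compounds below may be only part of what the source reports. "The series", "measured", "known", "first", "only" and "open" are said of these compounds alone.

In a functional assay on C8166 cells (Homo sapiens) for cytotoxicity, read by MTT assay (a lower number here means that less compound is tolerated, a higher number that more compound is tolerated), compound 1 (`Cc1cc(S(N)(=O)=O)ccc1NC(=O)COc1ccc(Cl)cc1NC(=O)c1cccc(Cl)c1`) gives 59700 nM and compound 2 (`Cc1cc(S(N)(=O)=O)ccc1NC(=O)COc1ccc(Cl)cc1NC(=O)c1ccc(Cl)cc1Cl`) gives 61100 nM. Among the compounds with values here, these are the only two numbers so far, and compound 2 stands level with compound 1, within the scatter.

Compound 3 (`Cc1cc(S(N)(=O)=O)ccc1NC(=O)COc1ccc(Cl)cc1NC(=O)c1cc(Cl)cc(Br)c1`) keeps the shared core and carries 3-bromo-5-chlorophenyl in place of 2,4-dichlorophenyl on a carbonyl carbon.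

Within the data shown here, only one measured step bears on this change: a 1.0-fold higher number from compound 1 to compound 2 (0.01 log units; within the scatter). It put 2,4-dichlorophenyl in place of 3-chlorophenyl on a carbonyl carbon and stayed within the scatter. So one change at this same place has left this assay flat, though a single step is thin evidence. Among the measured compounds shown here, no compound measured so far carries bromine, so the data say nothing directly about that part of the new group.

The expected change is a 1.1-fold lower number from compound 2 to compound 3 (0.05 log units; within the scatter), which means no step beyond the scatter is anticipated in either direction. For compound 3 the estimate is 55000 nM, with an expected range of 25000 nM to 115000 nM.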

Compound 3, half-maximal cytotoxic concentration: 114000 nM
Compound 3: middle estimate off by 2.1-fold (0.32 log units), on the low side, within the range that was stated.
By their numbers in this assay, from the lowest: compounds 1, 2 and 3 (each within the scatter of the next).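

In this assay, 3-bromo-5-chlorophenyl on a carbonyl carbon in place of 2,4-dichlorophenyl gives a 1.9-fold higher number from compound 2 to compound 3 (0.27 log units; within the scatter) and is the second change at this place to stay within the scatter. Within the data shown here, the first direct reading on bromine comes from bromo in place of hydrogen on an aromatic carbon, which gives a 1.9-fold higher number from compound 1 to compound 3 (0.28 log units; within the scatter) and so also produces no step beyond the scatter. The three halogenated phenyl groups at this position therefore stand within the scatter of one another in this assay, and no measured information is available to explain the sizes of these steps.

The compounds shown leave open whether this flat reading extends beyond chlorine and bromine on a phenyl ring, for example to an unsubstituted phenyl, a methoxy group or a pyridine ring on the same carbonyl carbon. They also leave open whether this assay would respond to a change elsewhere on the shared core, such as a carboxylic acid in place of the sulfonamide.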